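From 4-(1H-pyrazol-1-yl)phenyl to 6-phenylpyridin-3-yl in the series

The source may report more compounds than this note shows. Statements on the series, on what has been measured and on what is new or still open speak of the compounds shown alone.

In a functional assay on G-361 cells (Homo sapiens) for inhibition, with a stated time of 72 h (on this read-out higher numbers stand for weaker inhibition and lower numbers for stronger inhibition), compound 1 (`NC1CCC(Nc2nc(NCc3ccc(-c4ccccc4)cc3)c3ncn(C4CCCC4)c3n2)CC1`) gives 1020 nM and compound 2 (`NC1CCC(Nc2nc(NCc3ccc(-c4ccsc4)cc3)c3ncn(C4CCCC4)c3n2)CC1`) gives 570 nM with no separation beyond the scatter (a 1.8-fold lower number from compound 1 to compound 2 (0.25 log units; within the scatter)). Compound 3 (`NC1CCC(Nc2nc(NCc3ccc(-n4cccn4)cc3)c3ncn(C4CCCC4)c3n2)CC1`) gives 220 nM as the lowest number of the three, and the steps of a 4.6-fold lower number from compound 1 to compound 3 (0.67 log units; beyond the scatter) and a 2.6-fold lower number from compound 2 to compound 3 (0.41 log units; beyond the scatter) both place it clear of the other two.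

Compound 4 (`NC1CCC(Nc2nc(NCc3ccc(-c4ccccc4)nc3)c3ncn(C4CCCC4)c3n2)CC1`) departs from compound 3 (6-phenylpyridin-3-yl in place of 4-(1H-pyrazol-1-yl)phenyl on a saturated chain carbon bound to a nitrogen on an aromatic ring) through 6-phenylpyridin-3-yl in place of 4-(1H-pyrazol-1-yl)phenyl on a saturated chain carbon bound to a nitrogen on an aromatic ring. For the measured compounds named here, no measured step covers this exchange as a whole. The closest evidence is a 4.6-fold lower number from compound 1 to compound 3 (0.67 log units; beyond the scatter) where 1H-pyrazol-1-yl took the place of phenyl. Compound 4 carries a phenyl again, so that step is expected to run largely in reverse. On these data alone, the effect of the ring nitrogen in 6-phenylpyridin-3-yl is untested in these data, which leaves the size of the step uncertain.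

The expected change in this assay is a 3.0-fold higher number from compound 3 to compound 4 (0.47 log units; beyond the scatter) toward a higher number and of modest size. For compound 4 the estimated value is 650 nM with an expected range of 250 nM to 1600 nM on present evidence.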

Compound 4, half-maximal inhibitory concentration: 895 nM
For compound 4 the middle estimate is 1.4-fold (0.14 log units) below the measured one; low and high end bracket the measured number.
By their numbers in this assay, from the lowest: compound 3; then compounds 2, 4 and 1 (each within the scatter of the next).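

In this assay, the low number of compound 3 does not carry over to the 6-phenylpyridin-3-yl group, with a 4.1-fold higher number from compound 3 to compound 4 (0.61 log units; beyond the scatter), so the exchange on the saturated chain carbon bound to a nitrogen on an aromatic ring is a real step and not scatter. The ring nitrogen brings no separation from the all-carbon group, as a 1.1-fold lower number from compound 1 to compound 4 (0.06 log units; within the scatter) and a 1.6-fold higher number from compound 2 to compound 4 (0.20 log units; within the scatter) both stay within the scatter, leaving compounds 1, 2 and 4 as one group and compound 3, with the 4-(1H-pyrazol-1-yl)phenyl group, alone at the low end among these four compounds. No supporting data bear on why this exchange behaves as it does.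

The compounds shown leave open whether the pyrazole ring and the ring nitrogen can be combined, as in a 6-(1H-pyrazol-1-yl)pyridin-3-yl group, and whether such a group would stay with compound 3 or join the other three. They also leave open whether the low number belongs to pyrazole alone or extends to other five-membered rings with two hetero atoms, such as a 1H-imidazol-1-yl group on the same phenyl ring.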